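Swapping the Piperidinone for an Isobutylpiperidine

The compounds below may be only part of what the source reports. "The series", "measured", "known", "first", "only" and "open" are said of these compounds alone.

In an ADME assay on a cell-free system (plasma, Mus musculus) for metabolic stability, read by LC-MS, tested at 2 uM (a lower number here means that the compound disappears faster, a higher number that the compound lasts longer), compound 1 `CN1CCC(c2ccc3c(c2)oc(=O)n3C(=O)NCCCCc2ccccc2)CC1=O` gives 0.6 h. Compound 2 `CN1CCC(c2cc3oc(=O)n(C(=O)NCCCCc4ccccc4)c3cc2F)CC1` gives 0.333 h in this assay; the two numbers sit within the usual scatter of each other, so neither compound can be set apart from the other. Compound 3 `CC(C)CN1CCC(c2ccc3c(c2)oc(=O)n3C(=O)NCCCCc2ccccc2)CC1` is not yet measured. It differs from compound 1 in one place: 1-isobutylpiperidin-4-yl in place of 1-methyl-2-oxopiperidin-4-yl on an aromatic carbon. Among the measured compounds shown here, no measured pair shows what this exchange does. Because compound 1 gives 0.6 h and compound 2 gives 0.333 h with the same core, the expected step of no change at the digits printed from compound 1 to compound 3 (within the scatter) is none beyond the scatter. Compound 3 is expected to give 0.6 h, within 0.3 h to 1.2 h.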

Compound 3, half-life: 1 h
The estimate for compound 3 lay 1.7-fold (0.22 log units) below the measured number; low and high end bracket the measured number.
By their numbers in this assay, from the lowest: compounds 2, 1 and 3 (each within the scatter of the next, the first and the last beyond it).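

Among the compounds shown here, this is the first measured pair at this position: in this assay, 1-isobutylpiperidin-4-yl in place of 1-methyl-2-oxopiperidin-4-yl gives a 1.7-fold higher number from compound 1 to compound 3 (0.22 log units; within the scatter). The ring carbonyl can therefore go and isobutyl can replace methyl, together, without a step beyond the scatter. Nothing available explains this result.

Going by these compounds, the exchange makes both changes at once, so what each does alone stays open. Also open, on these data alone, is whether a longer chain, as in 1-hexylpiperidin-4-yl, or a ring, as in 1-benzylpiperidin-4-yl, would stay within the scatter of compound 1.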